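This account rests on a few compounds, and the source may have more. Where it says the series, first, only, none or still open, it means among the compounds named here.

In an ADME assay on L02 cells (Homo sapiens) for inhibition, read by CCK-8 assay, with a stated time of 48 h (on this read-out higher numbers stand for weaker inhibition of growth and lower numbers for stronger inhibition of growth), compound 1 (`Cc1ccccc1Nc1nc(Nc2ccc(N3CCCN(C)CC3)cc2)ncc1Cl`) gives 1240 nM and compound 2 (`CN1CCN(c2ccc(Nc3ncc(Cl)c(Nc4ccccc4)n3)nc2)CC1`) gives 7990 nM as its value. Compound 2 therefore has the higher of the two numbers, which means weaker inhibition of growth than compound 1, and the gap between them lies beyond the usual scatter. Among the compounds with values here, no two measured compounds differ in only one place, so no single structural change has yet been tested on these numbers.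

Compound 3 (`CN1CCN(c2ccc(Nc3ncc(Cl)c(NCc4ccc(F)cc4)n3)nc2)CC1`) departs from compound 2 in one place (4-fluorobenzyl in place of phenyl on a nitrogen on an aromatic ring), with 4-fluorobenzyl in place of phenyl on a nitrogen on an aromatic ring. The anilino group thus becomes a (4-fluorobenzyl)amino group. Within the data shown here, with no measured example of this swap, the expectation is anchored on compound 2 at 7990 nM and little else. The expected step is a 1.3-fold lower number from compound 2 to compound 3 (0.12 log units; within the scatter) and would be a small move toward stronger inhibition of growth, probably not beyond the scatter. The estimate for compound 3 is 6000 nM with an expected range from 2500 nM to 15000 nM as its likely span.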

Compound 3, concentration for 50% growth inhibition: 39700 nM
The estimate for compound 3 lay 6.6-fold (0.82 log units) below the measured number; the whole stated range lies below it.
By their numbers in this assay, from the lowest: compound 1; then compound 2; then compound 3.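

In this assay, putting 4-fluorobenzyl in place of phenyl on this nitrogen gives a 5.0-fold higher number from compound 2 to compound 3 (0.70 log units; beyond the scatter) and so moves the read-out toward weaker inhibition of growth, by more than the usual scatter. With the rest of the molecule unchanged, this shows that the group on this nitrogen can alter the result, which the first two compounds could not show because they differ in more than one place. Nothing measured here explains why the number rises.

The change also adds a carbon and a fluorine together, so this single step cannot assign the shift to either one, and plain benzyl and 4-fluorophenyl on the same nitrogen would be the groups needed to separate those two parts. Going by these compounds, it also remains open whether the trend continues with a longer chain such as 2-phenylethyl, or how a group of a different kind, such as a carboxylic acid, would behave at this position.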